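Methylating the phenol: compound 2 to compound 3

A few compounds are considered here, and "the series" means these few. Any claim that something is new, unique, unknown or untested is made for them only; others in the source may bear on it.

Compound 2 `COc1cc(OC)c(/C=C/S(=O)(=O)Cc2ccc(O)cc2)c(OC)c1` carries the common core with a hydroxy group on the pendant aromatic ring. In a functional assay on DLD-1 cells (Homo sapiens) for antiproliferative activity, read by trypan blue exclusion (a higher number here means a weaker inhibitor, a lower number a stronger inhibitor), compound 2 gives 20000 nM. Going by the values given here, its only measured neighbour is compound 1 `COc1cc(OC)c(/C=C/S(=O)(=O)Cc2ccc(C#N)cc2)c(OC)c1`, which bears a cyano group at the same carbon and in this assay gives 20000 nM. Among the compounds with values here, the one step between measured compounds, no change at the digits printed from compound 1 to compound 2 (within the scatter), shows that exchanging cyano for hydroxy left the reading where it was. Compound 2 therefore stands level with compound 1 at the digits recorded.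

Compound 3 `COc1ccc(CS(=O)(=O)/C=C/c2c(OC)cc(OC)cc2OC)cc1` has not yet been tested in this assay. Its difference from compound 2 is methyl in place of hydrogen on an oxygen on an aromatic ring, which read one bond further out is hydroxy to methoxy, or 4-hydroxyphenyl to 4-methoxyphenyl. Within the data shown here, the single step that bears on this position, no change at the digits printed from compound 1 to compound 2 (within the scatter), was flat, and it involved a larger change than capping the oxygen with a methyl. On that basis the expected step of no change at the digits printed from compound 2 to compound 3 (within the scatter) is none beyond the scatter. For compound 3 the estimated value in this assay is 20000 nM, with a range from 10000 nM to 40000 nM.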

Compound 3, half-maximal inhibitory concentration: 40 nM
Compound 3: the middle estimate sits 500-fold (2.70 log units) above what was measured; measured number outside the range, below it.
By their numbers in this assay, from the lowest: compound 3; then compounds 1 and 2 (each within the scatter of the next).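

In this assay, capping the oxygen on the aromatic ring with a methyl gives a 500-fold lower number from compound 2 to compound 3 (2.70 log units; beyond the scatter) and so turns a hydroxy group that had looked no different from a cyano group into a far stronger methoxy compound. The comparison at the same carbon agrees, with a 500-fold lower number from compound 1 to compound 3 (2.70 log units; beyond the scatter) standing in sharp contrast to the flat exchange of cyano for hydroxy, which means that the level shared by compound 1 and compound 2 was no general floor for this position and that the reading here depends strongly on which group sits on this carbon. Nothing available explains why the methyl has so large an effect.

The compounds shown leave open whether the effect is specific to methoxy or extends to other groups on this oxygen, such as an ethyl or a longer chain in place of the methyl. They also leave open how other groups on the same aromatic carbon would read in this series, for example an amine, a carboxylic acid or a simple methyl, and whether any of them would come close to compound 3.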